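Methoxy for amino on the aryl ketone of a shared core

A few compounds are considered here, and "the series" means these few. Any claim that something is new, unique, unknown or untested is made for them only; others in the source may bear on it.

Measured compounds:
compound 1 `COc1cc(-c2cc(/C=C/C(=O)c3ccc(N)cc3)[nH]n2)cc(OC)c1OC`: -1%
compound 2 `COc1ccc(C(=O)/C=C/c2cc(-c3cc(OC)c(OC)c(OC)c3)n[nH]2)cc1OC`: -89%

For the measured compounds named here, in a functional assay on OVCAR-8 cells (Homo sapiens) for cytotoxicity, read by sulforhodamine B assay, with a stated time of 48 h, tested at 10 uM (on this read-out lower numbers stand for a stronger effect and higher numbers for a weaker effect at the one concentration tested), compound 1 gives -1%, the highest of the two numbers measured so far; its nearest neighbour is compound 2, which differs by a single change on the carbonyl carbon and gives -89%, so that a number 88 percentage points lower from compound 1 to compound 2 (beyond the scatter). Compound 3 `COc1ccc(C(=O)/C=C/c2cc(-c3cc(OC)c(OC)c(OC)c3)n[nH]2)cc1` is not yet measured. It differs from compound 1 in one place: methoxy in place of amino on an aromatic carbon, the full change reading 4-aminophenyl to 4-methoxyphenyl. Going by the values given here, the only step that bears on it is the one from compound 1 to compound 2, where 3,4-dimethoxyphenyl replaced 4-aminophenyl on the same carbonyl carbon and the number fell far beyond the scatter. Compound 3 carries a single methoxy where compound 2 carries two, so a drop of similar direction is expected, though with more uncertainty. For compound 3 in this assay the expected step is therefore estimated as a number 64 percentage points lower from compound 1 to compound 3 (beyond the scatter). Compound 3 is therefore estimated at -65%, between -95% and -20%.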

Compound 3, a percentage reported as activity, at one concentration (the size of the read-out at that concentration, not a potency): -8%
Compound 3: middle estimate off by 57 percentage points, on the low side; the measured number lies above the stated range.
By their numbers in this assay, from the lowest: compound 2; then compounds 3 and 1 (each within the scatter of the next).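

In this assay, the amino to methoxy change on this aromatic carbon, para to a large group, does not by itself account for the large step seen earlier: a number 7 percentage points lower from compound 1 to compound 3 (within the scatter) is the whole of it. The large step instead appears with the second methoxy of the 3,4-dimethoxyphenyl group, since a number 81 percentage points higher from compound 2 to compound 3 (beyond the scatter) when that methoxy gives way to hydrogen, so within these compounds the effect goes with the 3,4-dimethoxyphenyl group rather than with loss of the amino group. No measurement is available that explains this difference.

The compounds shown leave open whether a lone methoxy on that ring carbon, as in a 3-methoxyphenyl group, would be enough. They also leave open whether a hydroxyl or a chlorine there could take the place of the second methoxy.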